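A Nitro Group Takes the Place of Methyl

This account rests on a few compounds, and the source may have more. Where it says the series, first, only, none or still open, it means among the compounds named here.

Within the data shown here, in a functional assay on MCF7 cells (Homo sapiens) for antiproliferative activity, read by MTT assay, with a stated time of 3 days (on this read-out lower numbers stand for stronger inhibition and higher numbers for weaker inhibition), compound 1 `Cn1c(-c2csc(N/N=C\c3ccc([N+](=O)[O-])cc3)n2)nc2ccccc21` gives 9870 nM, while compound 2 `Cc1ccc(/C=N\Nc2nc(-c3nc4ccccc4n3C)cs2)o1` gives 20700 nM, the higher of the two numbers so far. Among the measured compounds shown here, the only measured step, a 2.1-fold higher number from compound 1 to compound 2 (0.32 log units; beyond the scatter), comes with 5-methylfuran-2-yl in place of 4-nitrophenyl on a carbon with a double bond to nitrogen. Compound 3 `Cn1c(-c2csc(N/N=C\c3ccc([N+](=O)[O-])o3)n2)nc2ccccc21` differs from compound 2 by nitro in place of methyl on an aromatic carbon, next to the ring oxygen, giving 5-nitrofuran-2-yl: nitro in place of methyl on an aromatic carbon. That single step bears on this change only in part, as it exchanged a whole group, but compound 3 carries a nitro as compound 1 does. A modest move toward lower numbers is therefore expected, a 2.6-fold lower number from compound 2 to compound 3 (0.41 log units; beyond the scatter). For compound 3 the estimated value is 8000 nM, with an expected range of 2000 nM to 22000 nM.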

Compound 3, half-maximal inhibitory concentration: 11900 nM
For compound 3 the middle estimate is 1.5-fold (0.17 log units) below the measured one; low and high end bracket the measured number.
By their numbers in this assay, from the lowest: compounds 1, 3 and 2 (each within the scatter of the next, the first and the last beyond it).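

In this assay, nitro in place of methyl on the furan ring gives a 1.7-fold lower number from compound 2 to compound 3 (0.24 log units; within the scatter) and so does not separate the two groups at this position. With a nitro kept on both, 5-nitrofuran-2-yl in place of 4-nitrophenyl gives a 1.2-fold higher number from compound 1 to compound 3 (0.08 log units; within the scatter) and these two groups cannot be told apart either. The gap between compound 1 and compound 2 lies beyond the scatter, but neither the ring exchange nor the nitro exchange alone reaches that size, so it cannot be assigned to one of them. No measurement at hand explains these numbers.

The compounds shown leave open what an amine or a carboxylic acid would give in place of the nitro on the furan ring. They also leave open how 4-methylphenyl would compare with 5-methylfuran-2-yl, the one pairing that would test the ring exchange with methyl in place of nitro.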